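Phenyl in place of tert-butoxy on a carbonyl carbon

This account rests on a few compounds, and the source may have more. Where it says the series, first, only, none or still open, it means among the compounds named here.

Values in an ADME assay on CCRF-CEM cells (Homo sapiens) for cytotoxicity, with a stated time of 4 days; a higher number here means that more compound is tolerated, a lower number that less compound is tolerated
- compound 1 `CNC(=O)CCCCn1c(=O)c(C)cn([C@@H]2O[C@H](CO[Si](C)(C)C(C)(C)C)[C@@]3(OS(=O)(=O)C=C3N)[C@H]2O[Si](C)(C)C(C)(C)C)c1=O` gives 10000 nM
- compound 2 `Cc1cn([C@@H]2O[C@H](CO[Si](C)(C)C(C)(C)C)[C@@]3(OS(=O)(=O)C=C3N)[C@H]2O[Si](C)(C)C(C)(C)C)c(=O)n(C(=O)OC(C)(C)C)c1=O` gives 26000 nM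

Compound 2, at 26000 nM here, holds the higher of the two numbers, so it is the better tolerated of this pair. Compound 3 `Cc1cn([C@@H]2O[C@H](CO[Si](C)(C)C(C)(C)C)[C@@]3(OS(=O)(=O)C=C3N)[C@H]2O[Si](C)(C)C(C)(C)C)c(=O)n(C(=O)c2ccccc2)c1=O` keeps the shared core and puts phenyl in place of tert-butoxy on a carbonyl carbon. Going by the values given here, only one measured step bears on this, and only loosely: a 2.6-fold higher number from compound 1 to compound 2 (0.41 log units; beyond the scatter), a modest change that replaced the whole group on the aromatic nitrogen. Going from tert-butoxycarbonyl to benzoyl alters only part of that group, and no measurement yet shows the effect of phenyl here. A small downward step, no larger than the scatter, is therefore expected in this assay. The expected step is a 1.3-fold lower number from compound 2 to compound 3 (0.11 log units; within the scatter). For compound 3 the estimated value is 20000 nM, with an expected range of 8000 nM to 50000 nM for the measurement.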

Compound 3, half-maximal cytotoxic concentration: 54000 nM
Compound 3: middle estimate off by 2.7-fold (0.43 log units), on the low side; measured number above the stated range.
By their numbers in this assay, from the lowest: compound 1; then compound 2; then compound 3.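

On the carbonyl carbon attached to the aromatic nitrogen, replacing tert-butoxy with phenyl gives, in this assay, a 2.1-fold higher number from compound 2 to compound 3 (0.32 log units; beyond the scatter) and so shows that changing only part of the group on that nitrogen is enough to move the result. Replacing the whole 4-(methylcarbamoyl)butyl group with benzoyl gives a 5.4-fold higher number from compound 1 to compound 3 (0.73 log units; beyond the scatter) and this is the widest gap among the three compounds. Nothing available explains why phenyl is better tolerated here than tert-butoxy.

Still open, going by these compounds, is how a methyl group on that carbonyl carbon would behave, or a phenyl ring carrying an amine or a carboxylic acid. On these data alone, whether the same order of the three compounds would hold in other cell types also remains unknown.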